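A Methyl Step on the Lowest Number So Far

The source may report more compounds than this note shows. Statements on the series, on what has been measured and on what is new or still open speak of the compounds shown alone.

In a functional assay on ECV-304 cells (Homo sapiens), read by MTT assay, with stated times of 24 h and 12 h (on this read-out lower numbers stand for an effect already at smaller amounts and higher numbers for an effect only at larger amounts of compound), compound 1 (`COc1cc(C(=O)O)ccc1OCc1nc(C)c(C)nc1C`) gives 810000 nM and compound 2 (`Cc1nc(C)c(CNC(=O)CN2CCCC2=O)nc1C`) gives 1300000 nM while compound 3 (`Cc1nc(C)c(COc2ccc3ccc(=O)oc3c2)nc1C`) gives 140000 nM as the lowest of the three numbers, beyond the scatter from both others. Compound 4 (`Cc1nc(C)c(COc2ccc3c(C)cc(=O)oc3c2)nc1C`) differs from compound 3 by methyl in place of hydrogen on an aromatic carbon in one place, opposite the ring oxygen. Going by the values given here, no measured pair shows this kind of change, and the only guide is how small the change itself is. In this assay the expected move is small and toward a lower number, with the estimated 1.4-fold lower number from compound 3 to compound 4 (0.15 log units; within the scatter) staying within the scatter. The estimate for compound 4 is 100000 nM in this measurement, with an expected range from 40000 nM to 250000 nM around it.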

Compound 4, half-maximal effective concentration: 140000 nM
For compound 4 the middle estimate is 1.4-fold (0.15 log units) below the measured one; the measured number falls inside the stated range.
By their numbers in this assay, from the lowest: compounds 3 and 4 (each within the scatter of the next); then compounds 1 and 2 (each within the scatter of the next).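

Going by these compounds alone, this is the first pair in this assay that tests a single change, and methyl in place of hydrogen on an aromatic carbon, opposite the ring oxygen, gives no change at the digits printed from compound 3 to compound 4 (within the scatter). This position therefore carries one added carbon while the number stays within the scatter, and compounds 3 and 4 together remain apart from compounds 1 and 2. Nothing available explains this result.

On these data alone, whether ethyl, a longer chain or an amine in the same place would leave the number equally undisturbed remains open. One methyl at one position also says nothing about the other aromatic carbons of the shared core.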